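Swapping the aryl substituent within a pyrimidinyl amide series

This account rests on a few compounds, and the source may have more. Where it says the series, first, only, none or still open, it means among the compounds named here.

Compound 3 `CC(C)(C)c1ccc(NC(=O)C2=CCN(c3ncccn3)CC2)cc1` gives 10 nM in an in vitro functional assay on 1321-N1 cells for antagonist activity at transient receptor potential cation channel subfamily V member 1 (Homo sapiens), read by FLIPR and calcium flux (on this read-out higher numbers stand for weaker inhibition and lower numbers for stronger inhibition), the lowest of the three numbers measured. Compound 1 `O=C(Nc1ccc(S(=O)(=O)C(F)(F)F)cc1)C1=CCN(c2ncccc2Cl)CC1` gives 41 nM in this assay, and compound 2 `O=C(Nc1ccc(S(=O)(=O)C(F)(F)F)cc1)C1=CCN(c2nccs2)CC1` gives 95 nM. For the measured compounds named here, the only single change measured so far, a 2.3-fold higher number from compound 1 to compound 2 (0.36 log units; beyond the scatter), concerns the group on the amine nitrogen in a ring and does not touch the aryl substituent.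

Compound 4 `O=C(Nc1ccc(S(=O)(=O)C(F)(F)F)cc1)C1=CCN(c2ncccn2)CC1` differs from compound 3 by (trifluoromethyl)sulfonyl in place of tert-butyl on an aromatic carbon. Going by the values given here, no measured step follows this change directly. What the numbers show is that compound 1 and compound 2, which both carry the (trifluoromethyl)sulfonyl group, sit higher than compound 3 with its tert-butyl group, though they also differ in the group on the amine nitrogen in a ring, so the comparison is not clean.

Compound 4 is therefore expected to land somewhat above compound 3, an estimated step of a 3.0-fold higher number from compound 3 to compound 4 (0.48 log units; beyond the scatter) in this assay. The estimate for compound 4 is 30 nM, with a range from 8 nM to 120 nM.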

Compound 4, half-maximal inhibitory concentration: 44 nM
Beside the measured number, compound 4's estimate is 1.5-fold (0.17 log units) below it; the range from low to high includes it.
By their numbers in this assay, from the lowest: compound 3; then compounds 1 and 4 (each within the scatter of the next); then compound 2.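

In this assay the aryl substituent can now be read on its own: with pyrimidin-2-yl held fixed, (trifluoromethyl)sulfonyl in place of tert-butyl gives a 4.4-fold higher number from compound 3 to compound 4 (0.64 log units; beyond the scatter) and so weaker inhibition. With (trifluoromethyl)sulfonyl held fixed, the group on the amine nitrogen in a ring can also be compared more fully: pyrimidin-2-yl in place of 1,3-thiazol-2-yl gives a 2.2-fold lower number from compound 2 to compound 4 (0.33 log units; beyond the scatter) and so modestly stronger inhibition. Pyrimidin-2-yl in place of 3-chloropyridin-2-yl gives a 1.1-fold higher number from compound 1 to compound 4 (0.03 log units; within the scatter) and leaves these two groups indistinguishable here.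

No data at hand explain why these changes have the effects seen. Also open, as far as these compounds go, is how other groups on this aromatic carbon, such as a nitrile or a carboxylic acid, would compare with tert-butyl.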